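The compounds below may be only part of what the source reports. "The series", "measured", "known", "first", "only" and "open" are said of these compounds alone.

Measured compounds:
compound 1 `CC(C)c1noc(N2CCC(Oc3cc(N4CCc5cc(N6CC(O)CCC6=O)ccc54)ncn3)CC2)n1`, in an assay on CHO cells for agonist activity at Glucose-dependent insulinotropic receptor (Homo sapiens), read by a luciferase reporter and cAMP accumulation, with a stated time of 2 h (on this read-out lower numbers stand for an effect already at smaller amounts and higher numbers for an effect only at larger amounts of compound), compound 1 gives 90 nM
compound 2 `CC(C)c1noc(N2CCC(Oc3cc(N4CCc5cc(N6CCCS6(=O)=O)ccc54)ncn3)CC2)n1`, compound 2 gives 9.7 nM
compound 3 `CC(C)c1noc(N2CCC(Oc3cc(N4CCc5cc(N6CCCC6=O)ccc54)ncn3)CC2)n1`, compound 3 gives 33 nM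

Compound 3 stands second highest of the three numbers in this assay, with compound 1 nearest above it and compound 2 furthest below it. The next compound, compound 4 `CC(C)c1noc(N2CCC(Oc3cc(N4CCc5cc([S+]([O-])CCO)ccc54)ncn3)CC2)n1`, differs from compound 3 in one place: a group of 5 heavy atoms (2 carbon, 2 oxygen, 1 sulfur; no ring) in place of a group of 6 heavy atoms (4 carbon, 1 nitrogen, 1 oxygen; one five-membered non-aromatic ring with 1 hetero atom), on an aromatic carbon. The new group carries sulfur and a hydroxyl and has no ring.

Going by the values given here, three measured steps bear on this change. Exchanging the hydroxy-bearing lactam ring for a sulfur-bearing ring gave a 9.3-fold lower number from compound 1 to compound 2 (0.97 log units; beyond the scatter), the largest move in the set. Removing the hydroxyl while shortening the lactam ring gave a 2.7-fold lower number from compound 1 to compound 3 (0.44 log units; beyond the scatter). Going from the sulfur-bearing ring to the plain lactam gave a 3.4-fold higher number from compound 2 to compound 3 (0.53 log units; beyond the scatter). So the sulfur-containing ring helped, the hydroxyl hurt, and compound 4 combines a sulfur atom with a hydroxyl but in an open chain, for which no measured step exists. The two influences are expected to roughly cancel, so a 1.1-fold lower number from compound 3 to compound 4 (0.04 log units; within the scatter) is expected to stay near the scatter. Compound 4 is therefore estimated at 30 nM, within a range from 8 nM to 120 nM.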

Compound 4, half-maximal effective concentration: 48 nM
Compound 4: middle estimate off by 1.6-fold (0.20 log units), on the low side, within the range that was stated.
By their numbers in this assay, from the lowest: compound 2; then compounds 3, 4 and 1 (each within the scatter of the next, the first and the last beyond it).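

In this assay, the aromatic carbon that carries these groups tolerates a group with no ring: exchanging 2-oxopyrrolidin-1-yl for the open chain with sulfur and a hydroxyl gives a 1.5-fold higher number from compound 3 to compound 4 (0.16 log units; within the scatter), and exchanging the hydroxy-bearing lactam ring for the same chain gives a 1.9-fold lower number from compound 1 to compound 4 (0.27 log units; within the scatter), so among these compounds a ring at this place is not needed to stay in this range of numbers. Sulfur in the group does not by itself match the sulfur-bearing ring, as the step between those two groups gives a 4.9-fold higher number from compound 2 to compound 4 (0.69 log units; beyond the scatter), so compound 2 remains apart from compound 4 by more than the usual scatter. No measurement is available here that would explain these differences.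

On these data alone, the separate roles of the sulfur and the hydroxyl in the new chain remain open, as the two appear only together in compound 4. Also open, as far as these compounds go, is what would follow from an amine or a carboxylic acid in place of the hydroxyl, or from a longer chain between the sulfur and the end group.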